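The source may report more compounds than this note shows. Statements on the series, on what has been measured and on what is new or still open speak of the compounds shown alone.

Series notes. Compound 1 `Nc1scc(CN2CCN(c3cccc(Cl)c3Cl)CC2)c1C(=O)c1ccc(Cl)cc1`, compound 2 `Nc1scc(CN2CCN(c3ccc([N+](=O)[O-])cc3)CC2)c1C(=O)c1ccc(Cl)cc1` and compound 3 `Nc1scc(CN2CCN(c3ccc(Cl)c(C(F)(F)F)c3)CC2)c1C(=O)c1ccc(Cl)cc1` share one core and differ only in the group on the ring nitrogen. In an assay on CHO cells for displacement of a labelled ligand from adenosine receptor A3 (Homo sapiens), read by scintillation counting, with a stated time of 120 min, tested at 10 uM (a higher number here means more inhibition at the concentration tested (going by the name of the read-out), a lower number less inhibition), compound 1 gives 0%, compound 2 gives 2% and compound 3 gives 3%. As written, compound 3 carries the largest of the three numbers, yet a number 3 percentage points higher from compound 1 to compound 3 (within the scatter), a number 1 percentage points higher from compound 2 to compound 3 (within the scatter) and a number 2 percentage points higher from compound 1 to compound 2 (within the scatter) all lie within the scatter, so no order among the three is established. Compound 4 `Nc1scc(CN2CCN(C3CCCC3)CC2)c1C(=O)c1ccc(Cl)cc1` is unmeasured; its change from compound 3 is cyclopentyl in place of 4-chloro-3-(trifluoromethyl)phenyl on an amine nitrogen in a ring. Every measured step swaps one aromatic group for another on that nitrogen and none brings in a non-aromatic ring, so they bear on this step only in showing the read-out unmoved there so far. The step of no change at the digits printed from compound 3 to compound 4 (within the scatter) is expected, none beyond the scatter. Compound 4 is estimated at 3%, range -5% to 12%.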

Compound 4, a percentage reported as inhibition, at one concentration (the size of the read-out at that concentration, not a potency): 3%
Compound 4: middle estimate and measured number agree at the digits printed; low and high end bracket the measured number.
By their numbers in this assay, from the lowest: compounds 1, 2, 3 and 4 (each within the scatter of the next).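

Cyclopentyl brings a non-aromatic ring onto the amine nitrogen, and in this assay the read-out stays level with all three aromatic groups (no change at the digits printed from compound 3 to compound 4 (within the scatter)) and (a number 1 percentage points higher from compound 2 to compound 4 (within the scatter)) and (a number 3 percentage points higher from compound 1 to compound 4 (within the scatter)). Across these four compounds, neither an aromatic ring at this position nor the larger 4-chloro-3-(trifluoromethyl)phenyl group separates one compound from another. No evidence is available on what lies behind this flat read-out. From the compounds shown here alone, whether a carboxylic acid, a primary amine or a longer alkyl chain on that nitrogen would move the read-out remains open. So does the effect of any change elsewhere on the shared core.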